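Swapping the amine side chain for chlorine on the quinoline-type core

This account rests on a few compounds, and the source may have more. Where it says the series, first, only, none or still open, it means among the compounds named here.

Among the compounds with values here, compound 3 `C=CCOc1ccc2c(NCCCN(C)C)ccnc2c1` gives 3120 nM in a functional assay on NCI-H1650 cells (Homo sapiens) for cytotoxicity, read by MTT assay, with a stated time of 48 h (on this read-out lower numbers stand for stronger inhibition and higher numbers for weaker inhibition), the highest of the three numbers so far, although its gap to either neighbour lies within the scatter. Compound 1 `CC(C)COc1ccc2c(Cl)ccnc2c1` gives 2100 nM in this assay, and compound 2 `CCCCOc1ccc2c(Cl)ccnc2c1` gives 2570 nM. Within the data shown here, the only measured step, a 1.2-fold higher number from compound 1 to compound 2 (0.09 log units; within the scatter), touches the ether chain rather than the group on the ring carbon.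

Compound 4 `C=CCOc1ccc2c(Cl)ccnc2c1` differs from compound 3 by chloro in place of (3-(dimethylamino)propyl)amino on an aromatic carbon. Among the measured compounds shown here, no measured step covers this exchange directly; what the data offer is that compound 1 and compound 2, which both carry the chloro group alongside a saturated ether chain, sit close to compound 3. On that basis compound 4 is expected to land in the same region, with an estimated step of a 1.3-fold lower number from compound 3 to compound 4 (0.11 log units; within the scatter), not beyond the scatter. Compound 4 is therefore estimated at 2400 nM, with a range from 1000 nM to 6000 nM.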

Compound 4, half-maximal inhibitory concentration: 2280 nM
Estimate against measurement, compound 4: 1.1-fold (0.02 log units) above; measured number inside the range.
By their numbers in this assay, from the lowest: compounds 1, 4, 2 and 3 (each within the scatter of the next).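

In this assay, the exchange of (3-(dimethylamino)propyl)amino for chloro on the aromatic carbon opposite the ring nitrogen gives a 1.4-fold lower number from compound 3 to compound 4 (0.14 log units; within the scatter), so this assay does not separate these two groups at this position, despite the difference in their size. The ether chain also makes no measurable difference with chloro in place: vinyl in place of propyl gives a 1.1-fold lower number from compound 2 to compound 4 (0.05 log units; within the scatter) and vinyl in place of isopropyl gives a 1.1-fold higher number from compound 1 to compound 4 (0.04 log units; within the scatter), both within the scatter. Nothing available explains why these compounds read alike.

On these data alone, whether the chloro exchange reads the same alongside the propyl or isopropyl chain stays open. So does whether a carboxylic acid on this aromatic carbon, or a much longer chain on the ether oxygen, would move the number beyond the scatter.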